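Amide replacement on the shared core: compound 1 to compound 3

The source may hold more compounds than are shown below. What is called first, only, known or untested is meant among the compounds shown, and "the series" means these compounds.

Compound 1 `CCN(CC)S(=O)(=O)c1ccc(S(=O)(=O)N2CCC[C@@H](C(=O)N3CCC(F)(F)CC3)C2)cc1` gives 16 nM in a functional assay on MIA PaCa-2 cells (Homo sapiens) for inhibition, read by MTT assay, with a stated time of 7 days (on this read-out higher numbers stand for weaker inhibition and lower numbers for stronger inhibition), the highest of the two numbers in hand; compound 2 `O=C([C@@H]1CCCN(S(=O)(=O)c2ccc(S(=O)(=O)C3CCC3)cc2)C1)N1CCC(F)(F)CC1` gives 9 nM, and the step of a 1.8-fold lower number from compound 1 to compound 2 (0.25 log units; within the scatter) lies within the scatter. Compound 3 `CCN(CC)S(=O)(=O)c1ccc(S(=O)(=O)N2CCC[C@@H](C(=O)N[C@H]3CC[C@@H](OC)CC3)C2)cc1` differs from compound 1 by (4-methoxycyclohexyl)amino in place of 4,4-difluoropiperidin-1-yl on a carbonyl carbon. Among the compounds with values here, the only measured step sits on a sulfonyl sulfur and does not touch the carbonyl carbon, so nothing in hand bears on this change. No step beyond the scatter is expected, though the range is kept wide; the step of a 1.9-fold higher number from compound 1 to compound 3 (0.27 log units; within the scatter) is the estimate. Compound 3 is therefore expected at 30 nM, between 8 nM and 150 nM.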

Compound 3, half-maximal inhibitory concentration: 960 nM
For compound 3 the middle estimate is 32-fold (1.51 log units) below the measured one; measured number above the stated range.
By their numbers in this assay, from the lowest: compounds 2 and 1 (each within the scatter of the next); then compound 3.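

In this assay, within the data shown here, the amide on the carbonyl carbon proves sensitive to replacement: (4-methoxycyclohexyl)amino in place of 4,4-difluoropiperidin-1-yl gives a 60-fold higher number from compound 1 to compound 3 (1.78 log units; beyond the scatter), the only step in hand beyond the scatter. The entering group also brings a hydrogen-bond donor, a hydrogen-bond acceptor and 2 defined stereocentres, so this single swap changes several features at once. Nothing available explains the size of this step.

The compounds shown leave open which of these features goes with the step. They also leave open how a 4-methoxypiperidin-1-yl amide or an unsubstituted cyclohexylamino amide would compare on the same core.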